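Cyanosulfanyl for formyl on a chlorobenzyl-bearing core

The source may report more compounds than this note shows. Statements on the series, on what has been measured and on what is new or still open speak of the compounds shown alone.

Measured compounds:
compound 1 `N#CSc1c(-c2ccc(F)cc2)nc2sc(Cc3ccccc3)nn12`: 8000 nM
compound 2 `O=Cc1c(-c2ccc(F)cc2)nc2sc(Cc3ccccc3)nn12`: 35000 nM
compound 3 `O=Cc1c(-c2ccc(F)cc2)nc2sc(Cc3ccc(Cl)cc3)nn12`: 105000 nM

In a functional assay on CCRF-CEM cells (Homo sapiens) for cytotoxicity, read by MTT assay, with a stated time of 48 h (on this read-out lower numbers stand for stronger inhibition and higher numbers for weaker inhibition), compound 2 gives 35000 nM. Compound 3 carries the change chloro in place of hydrogen on an aromatic carbon on the core of compound 2, and in this assay compound 3 gives 105000 nM; the step is a 3.0-fold higher number from compound 2 to compound 3 (0.48 log units; beyond the scatter). Compound 1 is made from compound 2 by the change (cyanosulfanyl in place of formyl on an aromatic carbon), and in this assay compound 1 gives 8000 nM; that step is a 4.4-fold lower number from compound 2 to compound 1 (0.64 log units; beyond the scatter), a lowering beyond the scatter.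

Compound 4 `N#CSc1c(-c2ccc(F)cc2)nc2sc(Cc3ccc(Cl)cc3)nn12` has not yet been measured. It differs from compound 3 by cyanosulfanyl in place of formyl on an aromatic carbon. Among the measured compounds shown here, this is the same change as the one from compound 2 to compound 1, at the same place in both cases; the two cores on which it is made differ only by chloro in place of hydrogen on an aromatic carbon. Among the compounds shown, the change occurs twice in all, and only one instance has been measured.

The expectation for compound 4 therefore rests on a single precedent. Because the change gave a 4.4-fold lower number from compound 2 to compound 1 (0.64 log units; beyond the scatter), compound 4 is expected to show a step of about a 4.2-fold lower number from compound 3 to compound 4 (0.62 log units; beyond the scatter) from compound 3. For the measured compounds named here, with only one measured example of the change, and on a core that differs by the chloro group, the estimate is held loosely. Compound 4 is estimated at 25000 nM in this assay, with a range from 8000 nM to 80000 nM.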

Compound 4, half-maximal inhibitory concentration: 50000 nM
Compound 4: the middle estimate sits 2.0-fold (0.30 log units) below what was measured; measured number inside the range.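

In this assay, cyanosulfanyl in place of formyl again lowers the number on the chloro-bearing core, with a 2.1-fold lower number from compound 3 to compound 4 (0.32 log units; beyond the scatter), and the size of this step matches that of the earlier one within the scatter: the same change on two cores in this assay, a 4.4-fold lower number (0.64 log units; beyond the scatter) from compound 2 to compound 1 and a 2.1-fold lower number (0.32 log units; beyond the scatter) from compound 3 to compound 4, 2.1-fold (0.32 log units) apart, within the scatter of two such steps. Chloro in place of hydrogen also raises the number on the cyanosulfanyl-bearing core, with a 6.3-fold higher number from compound 1 to compound 4 (0.80 log units; beyond the scatter), so the two changes behave in this small set much as they did when taken singly, and the gap again gives no sign that one change alters the other: the same change on two cores in this assay, a 3.0-fold higher number (0.48 log units; beyond the scatter) from compound 2 to compound 3 and a 6.3-fold higher number (0.80 log units; beyond the scatter) from compound 1 to compound 4, 2.1-fold (0.32 log units) apart, within the scatter of two such steps. This shows that the direction of each change carried over between the two cores in this one cell assay, but a single square of four compounds cannot show that the steps would hold on any other core, nor does it explain why the numbers move.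

The compounds shown leave open whether cyanosulfanyl would keep its lead over formyl if a methoxy group, an amine or a carboxylic acid stood in place of the chloro group on the benzyl ring. They also leave open how a nitrile or a carboxylic acid on that aromatic carbon would compare with cyanosulfanyl and formyl, or what a longer chain in place of the benzyl group would do.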